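The source may report more compounds than this note shows. Statements on the series, on what has been measured and on what is new or still open speak of the compounds shown alone.

Measured so far:
compound 1, `CC(=O)N(C(C)=O)c1c(C#N)[n+]([O-])c2cc(Cl)ccc2[n+]1[O-]`: 3%
compound 2, `COc1ccc2c(c1)[n+]([O-])c(C(=O)N=[N+]=[N-])c(C)[n+]2[O-]`: 11.3%

Both numbers come from a functional assay on Ehrlich cells (Mus musculus) for cytotoxicity, read by trypan blue exclusion, with a stated time of 2 h, tested at 25 ug/mL; on this read-out higher numbers stand for a weaker effect at the one concentration tested and lower numbers for a stronger effect. In this assay compound 1 gives 3% and compound 2 gives 11.3%. Compound 2 stands highest of the two numbers shown, but its gap to compound 1 lies within the scatter, so the two compounds read alike on this read-out.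

Compound 3, `COc1ccc2c(c1)[n+]([O-])c(NC(=O)OC(C)C)c(C)[n+]2[O-]`, is not yet measured in this assay. It differs from compound 2 in one place: a group of 7 heavy atoms (4 carbon, 1 nitrogen, 2 oxygen; no ring) in place of a group of 5 heavy atoms (1 carbon, 3 nitrogen, 1 oxygen; no ring), on an aromatic carbon. Among the measured compounds shown here, no step between measured compounds is available, so the effect of such a change cannot be read from the series itself. Both measured numbers sit near the bottom of the scale, and the expectation is a small rise from compound 2 to compound 3, of about the size of the scatter or less. The estimated step is a number 4.7 percentage points higher from compound 2 to compound 3 (within the scatter). Compound 3 is expected to give 16%, within a range from 3% to 40%.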

Compound 3, a percentage reported as activity, at one concentration (the size of the read-out at that concentration, not a potency): 82.3%
Compound 3: the middle estimate sits 66.3 percentage points below what was measured; measured number above the stated range.
By their numbers in this assay, from the lowest: compounds 1 and 2 (each within the scatter of the next); then compound 3.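

Putting (isopropoxycarbonyl)amino in place of the group of 5 heavy atoms (1 carbon, 3 nitrogen, 1 oxygen), on the aromatic carbon next to the ring nitrogen, gives in this assay a number 71 percentage points higher from compound 2 to compound 3 (beyond the scatter). On this core, the position therefore decides whether the effect at the one concentration tested is strong or weak, which the two earlier numbers, from compounds differing in more than one place, could not show. No measurement at hand bears on the reason for this step.

Open, from the compounds shown here alone, is whether the weak effect of compound 3 belongs to the whole (isopropoxycarbonyl)amino group or to one part of it. A simple amine or a carboxylic acid at this position, or a longer chain in place of the isopropyl, would help separate these readings.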